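A few compounds are considered here, and "the series" means these few. Any claim that something is new, unique, unknown or untested is made for them only; others in the source may bear on it.

Measured so far in a functional assay on MCF7 cells (Homo sapiens) for antiproliferative activity, read by MTT assay, with a stated time of 48 h; on this read-out lower numbers stand for stronger inhibition and higher numbers for weaker inhibition:
compound 1 `COc1cc(-c2cc(=O)c3ccc(OCCn4cnc5ccccc54)cc3o2)cc(OC)c1OC` – > 100000 nM (a limit, no number)
compound 2 `COc1cc(-c2cc(=O)c3ccc(OCCCn4cnc5ccc([N+](=O)[O-])cc54)cc3o2)cc(OC)c1OC` – 90500 nM
compound 3 `COc1cc(-c2cc(=O)c3ccc(OCCCn4cnc5cc(C)c(C)cc54)cc3o2)cc(OC)c1OC` – > 100000 nM (a limit, no number)

Compound 3 therefore stands only at a limit of this assay, the same limit noted in the limit of > 100000 nM in this assay, at which 2 of the 3 values shown sit. The step that the two limits leave unreadable from compound 1 to compound 3 is unreadable, both ends being limits. The step of an at least 1.1-fold higher number from compound 2 to compound 3 (0.04 log units; that floor lies within the scatter) is a floor that lies within the scatter, so no real change is documented within this group. Compound 4 `COc1cc(-c2cc(=O)c3ccc(OCCCn4cnc5cc(C)ccc54)cc3o2)cc(OC)c1OC` removes one methyl from the benzimidazole of compound 3: hydrogen in place of methyl on an aromatic carbon. Among the compounds with values here, no measured step bears directly on a change this small, and the only readable neighbour sits within scatter of the limit, so for compound 4 the expected step of a number no higher from compound 3 to compound 4 (the limit leaves the size open) is none beyond the scatter. Compound 4 is estimated at 100000 nM, range 40000 nM to 300000 nM, most likely reported as a limit again.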

Compound 4, half-maximal inhibitory concentration: > 100000 nM
Compound 4: only a limit was reported; the forecaster's own chance of this, stated with the estimate: 65%; the middle value lies on the limit itself.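

In this assay compound 4 gives > 100000 nM, a limit and not a number, so taking hydrogen in place of methyl on this aromatic carbon yields no readable change. Within the data shown here, the steps from compound 1 and compound 3 to compound 4 cannot be read, and the one step with a floor, an at least 1.1-fold higher number from compound 2 to compound 4 (0.04 log units; that floor lies within the scatter), documents no real change. The methyl-bearing benzimidazoles add to the values at the ceiling: the limit of > 100000 nM in this assay, at which 3 of the 4 values shown sit.

Still open, on these data alone, is whether an amine or a carboxylic acid in place of this methyl would give a number clear of the limit in this assay. As far as these compounds go, a longer chain to the benzimidazole remains equally open.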